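The source may report more compounds than this note shows. Statements on the series, on what has been measured and on what is new or still open speak of the compounds shown alone.

In a functional assay on T47D cells (Homo sapiens) for inhibition (a lower number here means a stronger inhibitor, a higher number a weaker inhibitor), compound 3 `Oc1cccc(-c2cc(-c3ccccc3OC(F)(F)F)cc(-c3ccccc3O)n2)c1` gives 2680 nM, the lowest of the three numbers, yet within the scatter of compound 2 `Oc1cccc(-c2cc(-c3ccccc3C(F)(F)F)cc(-c3cccc(O)c3)n2)c1` at 4350 nM and of compound 1 `Oc1cccc(-c2cc(-c3ccccc3F)cc(-c3cccc(O)c3)n2)c1` at 4370 nM. Compound 4 `Oc1cccc(-c2cc(-c3ccccc3OC(F)(F)F)cc(-c3cccc(O)c3)n2)c1` differs from compound 3 in one place: 3-hydroxyphenyl in place of 2-hydroxyphenyl on an aromatic carbon. Among the measured compounds shown here, none of the measured steps bears on that change; the only one, a 1.0-fold lower number from compound 1 to compound 2 (0.00 log units; within the scatter), concerns the other aryl group and was flat. The hydroxyl position on this arm is therefore untested, and with compounds 1, 2 and 3 all lying within the scatter of one another, no step beyond the scatter is expected for a 1.3-fold higher number from compound 3 to compound 4 (0.12 log units; within the scatter). For compound 4 in this assay the estimate is 3500 nM, within 1700 nM to 7000 nM.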

Compound 4, half-maximal inhibitory concentration: 7950 nM
Compound 4: middle estimate off by 2.3-fold (0.36 log units), on the low side; the whole stated range lies below it.
By their numbers in this assay, from the lowest: compounds 3, 2, 1 and 4 (each within the scatter of the next, the first and the last beyond it).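

In this assay, among the compounds shown here, 3-hydroxyphenyl in place of 2-hydroxyphenyl next to the ring nitrogen gives a 3.0-fold higher number from compound 3 to compound 4 (0.47 log units; beyond the scatter), the first step beyond the scatter, so this position responds to where the hydroxyl stands. The changes on the other aryl group stay within the scatter, with trifluoromethoxy giving a 1.8-fold higher number from compound 2 to compound 4 (0.26 log units; within the scatter) and a 1.8-fold higher number from compound 1 to compound 4 (0.26 log units; within the scatter). No measurement shown accounts for the step at the hydroxyl.

As far as these compounds go, whether the same step appears with fluoro or trifluoromethyl on the other aryl group remains open. So does the effect of an amine or a carboxylic acid in place of the hydroxyl on this arm.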